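Benzyl for Fluorophenyl on the Piperazine Nitrogen

The source may report more compounds than this note shows. Statements on the series, on what has been measured and on what is new or still open speak of the compounds shown alone.

Compound 1 `Nc1ccccc1NC(=O)c1ccc(CSC(=S)N2CCN(c3ccc(F)cc3)CC2)cc1`: in a functional assay on A-375 cells (Homo sapiens) for antiproliferative activity, read by CCK-8 assay, with a stated time of 72 h, tested at 8 uM (a lower number here means a weaker effect, a higher number a stronger effect of the compound at the concentration tested), compound 1 gives 76.3%
Compound 2 `CC1CCCCN1C(=S)SCc1ccc(C(=O)Nc2ccccc2N)cc1`: compound 2 gives 85.2%
Compound 3 `Nc1ccccc1NC(=O)c1ccc(CSC(=S)N(Cc2ccccc2)Cc2ccccc2)cc1`: compound 3 gives 32.5%

Compound 1 stands second highest of these three numbers. Its value and that of compound 2 lie within the usual scatter of each other, so no order can be drawn between them, while compound 3 lies well below compound 1, beyond the scatter. Compound 4 `Nc1ccccc1NC(=O)c1ccc(CSC(=S)N2CCN(Cc3ccccc3)CC2)cc1` has not yet been measured. It differs from compound 1 in one place: benzyl in place of 4-fluorophenyl on an amine nitrogen in a ring. Among the compounds with values here, no step between measured compounds isolates this change. Within the data shown here, compound 3, the only measured compound carrying a benzyl group, gives 32.5%, so a downward step of modest size is expected, possibly no larger than the scatter. Compound 4 is expected to give about 65%, in the range 40% to 85%. That estimate means an expected step of a number 11.3 percentage points lower from compound 1 to compound 4 (beyond the scatter) in this assay.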

Compound 4, a percentage reported as inhibition, at one concentration (the size of the read-out at that concentration, not a potency): 29.3%
Compound 4: middle estimate off by 35.7 percentage points, on the high side; the whole stated range lies above it.
By their numbers in this assay, from the lowest: compounds 4 and 3 (each within the scatter of the next); then compounds 1 and 2 (each within the scatter of the next).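

In this assay, within the data shown here, this is the first step that isolates the group on this ring nitrogen, and it shows that the position is sensitive: benzyl in place of 4-fluorophenyl gives a number 47 percentage points lower from compound 1 to compound 4 (beyond the scatter). The two groups match in heavy-atom count and each carries one six-membered aromatic ring of carbon only, yet the step is large. Nothing measured here bears on why this is so.

The compounds shown leave open whether the loss of fluorine or the added methylene link carries the step. A plain phenyl or a 4-fluorobenzyl group on this nitrogen would separate the two.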